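A few compounds are considered here, and "the series" means these few. Any claim that something is new, unique, unknown or untested is made for them only; others in the source may bear on it.

Compounds measured in a functional assay on RXF 393 cells (Homo sapiens) for inhibition; a lower number here means a stronger inhibitor of growth, a higher number a weaker inhibitor of growth:
compound 1 `COc1cccc(-c2nn(-c3ccccc3)cc2-c2ccnc(NCCNC(=O)Nc3cccc(C(F)(F)F)c3)c2)c1`, 4630 nM
compound 2 `COc1cccc(-c2nn(-c3ccccc3)cc2-c2ccnc(NCCCNC(=O)Nc3ccc(Cl)c(Cl)c3)c2)c1`, 4870 nM
compound 3 `O=C(NCCCNc1cc(-c2cn(-c3ccccc3)nc2-c2cccc(O)c2)ccn1)c1ccccc1`, 6200 nM

Compound 3 gives the highest of the three numbers, yet its gaps to compound 2 and to compound 1 both lie within the scatter, so the three cannot be ranked on these data. Compound 4 `O=C(NCCCNc1cc(-c2cn(-c3ccccc3)nc2-c2cccc(O)c2)ccn1)c1ccc(F)cc1` differs from compound 3 in one place: fluoro in place of hydrogen on an aromatic carbon. Going by the values given here, no step between two measured compounds is available to size such a change in this assay. A single fluoro replacing hydrogen is therefore expected to move the number little, with no direction beyond the scatter. Compound 4 is accordingly estimated at 5500 nM, between 2500 nM and 12000 nM, a step of a 1.1-fold lower number from compound 3 to compound 4 (0.05 log units; within the scatter) that is expected to stay within the scatter.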

Compound 4, concentration for total growth inhibition: 3030 nM
The estimate for compound 4 lay 1.8-fold (0.26 log units) above the measured number; the measured number falls inside the stated range.
By their numbers in this assay, from the lowest: compounds 4, 1, 2 and 3 (each within the scatter of the next, the first and the last beyond it).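

In this assay, going by these compounds alone, fluoro in place of hydrogen on the benzoyl ring gives a 2.0-fold lower number from compound 3 to compound 4 (0.31 log units; beyond the scatter) and so provides the first sized change at this position. This modest step lies beyond the scatter, showing that the number responds to a single fluoro on this ring, para to a large group, and that it moves downward. Nothing available here explains the step.

Going by these compounds, whether this is particular to fluoro remains open, since chloro, methoxy or trifluoromethyl at the same carbon could show. Also open, on these data alone, is whether the step would carry over to the urea compounds.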